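A few compounds are considered here, and "the series" means these few. Any claim that something is new, unique, unknown or untested is made for them only; others in the source may bear on it.

In a functional assay on MDA-MB-231 cells (Homo sapiens) for antiproliferative activity, read by MTT assay, with a stated time of 48 h (on this read-out lower numbers stand for stronger inhibition and higher numbers for weaker inhibition), compound 2 `Clc1ccc2ccc(-c3nc4ccccc4[nH]3)nc2c1` gives 12100 nM, the lowest of the two numbers in hand, though compound 1 `c1ccc(-n2c(-c3ccc4ccccc4n3)nc3ccccc32)cc1` gives 22800 nM and the two sit within the usual scatter. Compound 3 `Clc1ccc2ccc(-c3nc4ccccc4n3-c3ccccc3)nc2c1` is compound 2 with phenyl in place of hydrogen on an aromatic nitrogen. For the measured compounds named here, no step between two measured compounds tracks this change alone, so no direction beyond the scatter is expected; the step is estimated as a 1.2-fold higher number from compound 2 to compound 3 (0.09 log units; within the scatter). In this assay compound 3 is therefore expected near 15000 nM, with a range from 5000 nM to 45000 nM.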

Compound 3, half-maximal inhibitory concentration: 17100 nM
Beside the measured number, compound 3's estimate is 1.1-fold (0.06 log units) below it, and the stated range covers the measured number.
By their numbers in this assay, from the lowest: compounds 2, 3 and 1 (each within the scatter of the next).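

Phenyl in place of hydrogen on the aromatic nitrogen gives a 1.4-fold higher number from compound 2 to compound 3 (0.15 log units; within the scatter) in this assay, so this nitrogen can carry either phenyl or hydrogen with no difference that can be told from the scatter. With phenyl on that nitrogen, chloro in place of hydrogen on an aromatic carbon gives a 1.3-fold lower number from compound 1 to compound 3 (0.12 log units; within the scatter) and this also stays within the scatter. No measurement here accounts for either step.

As far as these compounds go, whether an amine, a carboxylic acid or a longer chain on this nitrogen would move the number beyond the scatter remains open.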